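This account rests on a few compounds, and the source may have more. Where it says the series, first, only, none or still open, it means among the compounds named here.

Measured compounds:
compound 1 `CNC1=C(Cl)C(=O)c2ncccc2C1=O` gives 78900 nM in a functional assay on cells (Neutrophil, Homo sapiens) for inhibition, read by WST assay, with a stated time of 20 min; a lower number here means a stronger inhibitor, a higher number a weaker inhibitor;
compound 2 `CNC1=C(Cl)C(=O)c2cccnc2C1=O` gives 41100 nM in this assay;
compound 3 `CNC1=C(SC)C(=O)c2ncccc2C1=O` gives > 200000 nM in this assay, which is a limit of the assay.

Compound 3 thus sits at the limit described in the limit of > 200000 nM in this assay, at which 1 of the 3 values shown sits, the only one of the three without a number. Compound 4 `CNC1=C([S+](C)[O-])C(=O)c2ncccc2C1=O` differs from compound 3 by a group of 3 heavy atoms (1 carbon, 1 oxygen, 1 sulfur; no ring) in place of a group of 2 heavy atoms (1 carbon, 1 sulfur; no ring), on a double-bonded ring carbon. For the measured compounds named here, no measured pair covers this change. Going by the values given here, the only step that touches the methylsulfanyl group is an at least 2.5-fold higher number from compound 1 to compound 3 (0.40 log units; beyond the scatter), which carried compound 3 out of the numbered range. Compound 4 is therefore expected to remain around or beyond that limit, with an expected step that the limit leaves unreadable from compound 3 to compound 4. The estimate for compound 4 in this assay is 250000 nM, ranging from 80000 nM to 1000000 nM.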

Compound 4, half-maximal inhibitory concentration: > 200000 nM
Compound 4: only a limit was reported (the forecaster's own chance of this, stated with the estimate: 70%); the middle value is on the limit's open side.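

In this assay, the group of 3 heavy atoms in place of chlorine on this double-bonded ring carbon gives an at least 2.5-fold higher number from compound 1 to compound 4 (0.40 log units; beyond the scatter), so methylsulfanyl is no longer the only replacement of chlorine here that leaves the numbered range. Compound 4 sits at a limit of the assay, as does compound 3, so the step between them cannot be read: the limit of > 200000 nM in this assay, at which 2 of the 4 values shown sit.

The compounds shown leave open how an amine or a longer chain on this carbon would read in this assay, and whether these sulfur-bearing groups would act alike on the core of compound 2, which gives 41100 nM.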